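A few compounds are considered here, and "the series" means these few. Any claim that something is new, unique, unknown or untested is made for them only; others in the source may bear on it.

Compound 1 `COc1cc(-c2ccnc3cc(-c4cn(CO)c5ccccc45)nn23)cc(OC)c1OC` gives 128 nM
Compound 2 `COc1cc(-c2ccnc3cc(-c4c[nH]c5ccccc45)nn23)cc(OC)c1OC` gives 35 nM
Compound 3 `COc1cc(-c2ccnc3cc(-c4cccc(C#N)c4)nn23)cc(OC)c1OC` gives > 10000 nM which is a limit of the assay, not a number

In a functional assay on HCT-116 cells (Homo sapiens) for inhibition, read by CCK-8 assay, with a stated time of 48 h (on this read-out higher numbers stand for weaker inhibition and lower numbers for stronger inhibition), compound 2 has the lower of the two true numbers. Compound 4 `COc1cc(-c2ccnc3cc(-c4ccccc4)nn23)cc(OC)c1OC` differs from it by one change: phenyl in place of 1H-indol-3-yl on an aromatic carbon with phenyl in place of 1H-indol-3-yl on an aromatic carbon. The closest guide is an at least 280-fold higher number from compound 2 to compound 3 (2.45 log units; beyond the scatter) where 3-cyanophenyl takes the place of the same group. The other measured step, a 3.7-fold lower number from compound 1 to compound 2 (0.56 log units; beyond the scatter) and modest in size, concerns a different place and bears on this change only weakly. A large step towards a higher number, meaning weaker inhibition, is therefore expected in this assay and the estimated move is an 86-fold higher number from compound 2 to compound 4 (1.93 log units; beyond the scatter). For compound 4 the expected value is 3000 nM with an estimated range from 400 nM to 10000 nM.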

Compound 4, half-maximal inhibitory concentration: 3880 nM
For compound 4 the middle estimate is 1.3-fold (0.11 log units) below the measured one; measured number inside the range.
By their numbers in this assay, from the lowest: compound 2; then compound 1; then compound 4. At a limit, above all of these: compound 3.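

In this assay, bare phenyl in place of 1H-indol-3-yl already loses most of the inhibition, with a 110-fold higher number from compound 2 to compound 4 (2.04 log units; beyond the scatter), so this loss does not need the cyano group. Hydrogen in place of cyano gives an at least 2.5-fold lower number from compound 3 to compound 4 (0.41 log units; beyond the scatter), so the cyano group only adds to the loss. The value of compound 3 is a limit, not a number, and that step has no upper end: the limit of > 10000 nM in this assay, at which 1 of the 4 values shown sits.

Phenyl removes the five-membered ring and its ring-nitrogen hydrogen together, and which of them counts stays open. As far as these compounds go, whether an amine or a hydroxyl on the phenyl would restore inhibition also stays open.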